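This account rests on a few compounds, and the source may have more. Where it says the series, first, only, none or still open, it means among the compounds named here.

Series notes. In a functional assay (Oryctolagus cuniculus) for inhibition (on this read-out higher numbers stand for weaker inhibition and lower numbers for stronger inhibition), compound 2 `CC(=O)OCCOCn1cnc2c(Cl)nc(Cl)nc21` gives 10 ug/mL. Compound 1 `OCCOCn1cnc2c(O)ncnc21` returns only a limit of the assay, > 100 ug/mL, and no number. Compound 3 `Nc1nc2c(nc(Cl)n2COCCO)c(=O)[nH]1` also sits at a limit of the assay, > 400 ug/mL, so on the values shown it is one of two compounds known only by a limit. Compound 4 `CN(C)c1nc2c(=O)[nH]c(N)nc2n1COCCO` is not yet measured; it differs from compound 3 by dimethylamino in place of chloro on an aromatic carbon. Among the measured compounds shown here, no step between measured compounds is recorded for a change of this kind, and no direction can be read from the series. The step is expected to be none beyond the scatter, a number no higher from compound 3 to compound 4 (the limit leaves the size open). Compound 4 is estimated at 400 ug/mL, within 100 ug/mL to 1000 ug/mL, most probably reported again as a limit.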

Compound 4, concentration for 50% inhibition: > 400 ug/mL
Compound 4 was reported as a limit; the forecaster's own chance of this, stated with the estimate: 70%; the middle value sits exactly at the limit.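

Compound 3 and compound 4 are both known only by a limit of the assay, so no step can be read between them. The compounds shown leave open whether dimethylamino in place of chloro on an aromatic carbon changes inhibition at all.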